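A few compounds are considered here, and "the series" means these few. Any claim that something is new, unique, unknown or untested is made for them only; others in the source may bear on it.

Measured so far:
Compound 1 `O=C(Nc1cc(-c2ccccn2)n[nH]1)N1CCC(c2ccc(Cl)cc2)CC1` gives > 55000 nM in an ADME assay on cells (Peritoneal macrophage cell, Mus musculus) for cytotoxicity, read by fluorescence and resazurin assay, with a stated time of 3 days (on this read-out higher numbers stand for lower toxicity in this test and lower numbers for higher toxicity in this test), a limit of the assay rather than a number.
Compound 2 `COc1ccccc1C(=O)Nc1[nH]nc(-c2ccccn2)c1C1CC1` gives > 51000 nM in this assay, again a limit.
Compound 3 `O=C(Nc1cc(-c2ccccn2)n[nH]1)N1CCC(Oc2ccccc2)CC1` gives > 40000 nM in this assay, likewise a limit.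

Compound 2 therefore stands only at a limit on the numbers shown, as do the two other measured values, which sit at the limit of > 55000 nM in this assay, at which 1 of the 3 values shown sits, and (the limit of > 40000 nM in this assay, at which 1 of the 3 values shown sits); its own sits at the limit of > 51000 nM in this assay, at which 1 of the 3 values shown sits. No ordering among the three compounds can be read from these limits.

The step from compound 2 to compound 4 `O=C(Nc1[nH]nc(-c2ccccn2)c1C1CC1)c1c(Cl)cccc1Cl` is 2,6-dichlorophenyl in place of 2-methoxyphenyl on a carbonyl carbon. Among the measured compounds shown here, the only measured step, a step that the two limits leave unreadable from compound 1 to compound 3, is unreadable in size, and it concerns a different part of the shared core, so it bears on this change only in showing that both ends stayed at a limit. No measured value gives a direction for a change on the carbonyl carbon; with every measured compound at a limit, no step beyond the scatter is expected in this assay, and compound 4 is expected to remain at or near a limit as well.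

Compound 4 is therefore estimated at 50000 nM, with a range of 20000 nM to 100000 nM, so that the expected step of an at least 1.0-fold lower number from compound 2 to compound 4 (0.00 log units; that floor lies within the scatter) stays within the scatter.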

Compound 4, half-maximal cytotoxic concentration: > 64000 nM
Compound 4: a limit, no number; the forecaster's own chance of this, stated with the estimate: 70%; middle value at least 1.2-fold (0.10 log units) from the limit.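

Compound 2 and compound 4 both stand only at limits in this assay, so no step can be read for 2,6-dichlorophenyl in place of 2-methoxyphenyl on a carbonyl carbon. The compounds shown leave open where any of them reaches its half-maximal cytotoxic concentration, and whether any change on the shared core shifts it.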